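Adding a methoxy group to the phenylpiperazine of compound 2

A few compounds are considered here, and "the series" means these few. Any claim that something is new, unique, unknown or untested is made for them only; others in the source may bear on it.

Of the compounds shown here, two of a shared core have been measured so far. Compound 1, `COc1cccc(N2CCN(CCCC(=O)Nc3ccc(Cl)cc3)CC2)c1`, carries a methoxy group on the aryl ring attached to the piperazine and a single chlorine on the anilide; in an assay on HEK293 cells for inhibition of Voltage-dependent T-type calcium channel subunit alpha-1G (Homo sapiens), read by patch clamp, tested at 10 uM (a higher number here means more inhibition at the concentration tested (going by the name of the read-out), a lower number less inhibition), compound 1 gives 84.1%. Compound 2, `O=C(CCCN1CCN(c2ccccc2)CC1)Nc1ccc(Cl)cc1Cl`, lacks the methoxy group and carries two chlorines on the anilide; in this assay compound 2 gives 76.2%. Compound 2 thus has the lower of the two numbers, but compound 1 lies only a few points higher, within the scatter of the measurement, so the two are best read as alike.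

Compound 3, `COc1cccc(N2CCN(CCCC(=O)Nc3ccc(Cl)cc3Cl)CC2)c1`, is compound 2 with one change: methoxy in place of hydrogen on an aromatic carbon, on an aromatic carbon of a six-membered aromatic ring of carbon only, meta to a large group. Among the measured compounds shown here, no measured pair isolates this change. Since compound 1 and compound 2 sit within the scatter of each other, the step in this assay is expected to be small, a number 3.8 percentage points higher from compound 2 to compound 3 (within the scatter), with no direction beyond the scatter. Compound 3 is therefore estimated at 80%, between 65% and 92%.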

Compound 3, a percentage reported as inhibition, at one concentration (the size of the read-out at that concentration, not a potency): 80.3%
For compound 3 the middle estimate is 0.3 percentage points below the measured one; the measured number falls inside the stated range.
By their numbers in this assay, from the lowest: compounds 2, 3 and 1 (each within the scatter of the next).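

In this assay, among the compounds shown here, the two new steps give the first direct reading of each change on the shared core: methoxy in place of hydrogen on an aromatic carbon, meta to a large group, gives a number 4.1 percentage points higher from compound 2 to compound 3 (within the scatter), while chloro in place of hydrogen on an aromatic carbon gives a number 3.8 percentage points lower from compound 1 to compound 3 (within the scatter). Neither change moves the read-out beyond the scatter, so on this core and at this single tested concentration, the phenyl to 3-methoxyphenyl exchange and the added chlorine on the anilide both leave the inhibition indistinguishable from that of the compound they modify. Nothing measured here accounts for this lack of separation.

The compounds shown leave open whether a group of another kind on this aromatic carbon, such as an amine or a carboxylic acid, would give a step beyond the scatter. They also leave open whether a longer chain in place of the one in the shared core would do so, and whether the close readings seen here would persist in a true measure of potency rather than a read-out at one concentration.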